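Compound 4 weighed against the limit reached by compound 2

The source may hold more compounds than are shown below. What is called first, only, known or untested is meant among the compounds shown, and "the series" means these compounds.

Three compounds share a core and differ in the chain and the amide end. In an assay on isolated protein (Mus musculus) for inhibition of IL15-IL15 receptor (Homo sapiens), read by resazurin assay, with stated times of 30 min and 2.5 days (on this read-out higher numbers stand for weaker inhibition and lower numbers for stronger inhibition), compound 1 `Cn1c(Cc2nn(C)c(=O)c3ccccc23)nnc1SCCCC(=O)Nc1ccc(Cl)cc1Cl` gives 9800 nM, and compound 3 `Cn1c(Cc2nn(C)c(=O)c3ccccc23)nnc1SCCCCCCCC(=O)Nc1ccc(Cl)cc1` gives 800 nM. Compound 2 `CN(C(=O)CSc1nnc(Cc2nn(C)c(=O)c3ccccc23)n1C)c1ccc(Cl)cc1Cl` stands at the limit of > 30000 nM in this assay, at which 1 of the 3 values shown sits. In this assay compound 2 reports only the limit > 30000 nM, not a number. Compound 4 `Cn1c(Cc2nn(C)c(=O)c3ccccc23)nnc1SCC(=O)Nc1ccc(I)cc1` differs from compound 2 by (4-iodophenyl)amino in place of (2,4-dichlorophenyl)(methyl)amino on a carbonyl carbon, so a hydrogen-bond donor returns at the amide while the short chain stays. Compound 1 and compound 3, both carrying an amide hydrogen, show measured values rather than a limit, so the step of an at least 2.5-fold lower number from compound 2 to compound 4 (0.39 log units; beyond the scatter) is expected to be a gain beyond the scatter, yet modest. Compound 4 is expected to give about 12000 nM, within 3000 nM to 40000 nM.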

Compound 4, half-maximal inhibitory concentration: "not active" (no number reported)
Compound 4: no number reported; the estimate stays without a comparison.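

No step can be read between compound 2 and compound 4: compound 4 is reported as "not active" without a number, and compound 2 stands only at a limit. The compounds shown leave open whether (4-iodophenyl)amino in place of (2,4-dichlorophenyl)(methyl)amino changes inhibition at all.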